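Notes on the series: 3-chlorophenyl to 4-cyanophenyl

A few compounds are considered here, and "the series" means these few. Any claim that something is new, unique, unknown or untested is made for them only; others in the source may bear on it.

Compound 1 `COc1cccc(Nc2nc(Nc3cc(C)[nH]n3)cc(N3CCN(C)CC3)n2)c1`: 509 nM
Compound 2 `Cc1cc(Nc2cc(N3CCN(C)CC3)nc(Nc3cccc(Cl)c3)n2)n[nH]1`: 97.2 nM

Both values come from a functional assay on K562 cells (Homo sapiens) for antiproliferative activity, read by CCK-8 assay, with a stated time of 72 h; on this read-out higher numbers stand for weaker inhibition and lower numbers for stronger inhibition. Compound 2 has the lower of the two numbers, at 97.2 nM. Among the compounds with values here, the only measured step is a 5.2-fold lower number from compound 1 to compound 2 (0.72 log units; beyond the scatter), with chloro in place of methoxy on an aromatic carbon.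

Compound 3 `Cc1cc(Nc2cc(N3CCN(C)CC3)nc(Nc3ccc(C#N)cc3)n2)n[nH]1` is the next to be read. Its difference from compound 2 is 4-cyanophenyl in place of 3-chlorophenyl on a nitrogen on an aromatic ring. Within the data shown here, the single measured step bears on this change only loosely. Among the measured compounds shown here, it shows that the read-out can move when a substituent on this aromatic ring is exchanged, but no measured compound carries a nitrile or a 4-substituted ring. The guide for size is therefore a 5.2-fold lower number from compound 1 to compound 2 (0.72 log units; beyond the scatter), and a modest move toward a higher number is expected, although the direction is uncertain with so few data. The estimate is a 2.1-fold higher number from compound 2 to compound 3 (0.31 log units; beyond the scatter). For compound 3 the expected value is 200 nM, with an estimated range of 55 nM to 750 nM.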

Compound 3, half-maximal inhibitory concentration: 58.1 nM
Compound 3: the middle estimate sits 3.4-fold (0.54 log units) above what was measured; the range from low to high includes it.
By their numbers in this assay, from the lowest: compounds 3 and 2 (each within the scatter of the next); then compound 1.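

In this assay, 4-cyanophenyl in place of 3-chlorophenyl on the nitrogen gives a 1.7-fold lower number from compound 2 to compound 3 (0.22 log units; within the scatter) and so no separable change: this position takes either ring with the read-out unmoved beyond the scatter. Set against 3-methoxyphenyl, the same ring gives an 8.8-fold lower number from compound 1 to compound 3 (0.94 log units; beyond the scatter) and is clearly apart from it, so compound 1 now differs beyond the scatter from two compounds with different ring substituents rather than from one. Nothing at hand accounts for either step.

From the compounds shown here alone, the step from 3-chlorophenyl to 4-cyanophenyl changes both the group and its place on the ring, so the part played by each remains open; a pair such as 3-cyanophenyl and 4-chlorophenyl would separate them. Also open, going by these compounds, is how far this position tolerates a wider range of groups on the ring, such as a carboxylic acid or a dimethylamino group in place of the nitrile, and whether the flat response seen for compound 2 and compound 3 would hold for them.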